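Catechol in place of fluorophenyl on the hydrazone carbon

This account rests on a few compounds, and the source may have more. Where it says the series, first, only, none or still open, it means among the compounds named here.

Three compounds share one core and differ only in the group on the carbon with a double bond to nitrogen. Compound 1 `COc1ccc(/C=N/NC(=O)CSc2nnc(-c3ccncc3)n2-c2ccccc2)cc1` gives 19200 nM in a functional assay on HCT-116 cells (Homo sapiens) for inhibition, read by MTT assay, with a stated time of 48 h; a lower number here means a stronger inhibitor, a higher number a weaker inhibitor. Compound 2 `O=C(CSc1nnc(-c2ccncc2)n1-c1ccccc1)N/N=C/c1ccc([N+](=O)[O-])cc1` gives 10200 nM in this assay, and compound 3 `O=C(CSc1nnc(-c2ccncc2)n1-c1ccccc1)N/N=C/c1ccccc1F` gives 18000 nM in this assay. Compound 3 stands second highest of these three numbers; its nearest neighbour is compound 1 and the furthest is compound 2, and each step among them, a 1.9-fold lower number from compound 1 to compound 2 (0.27 log units; within the scatter), a 1.1-fold lower number from compound 1 to compound 3 (0.03 log units; within the scatter) and a 1.8-fold higher number from compound 2 to compound 3 (0.25 log units; within the scatter), lies within the scatter. Compound 4 `O=C(CSc1nnc(-c2ccncc2)n1-c1ccccc1)N/N=C/c1ccc(O)c(O)c1` carries a change of the same kind: 3,4-dihydroxyphenyl in place of 2-fluorophenyl on a carbon with a double bond to nitrogen. All three measured steps concern a swap of the group at this same place and none of them left the scatter, so compound 4 is expected to show no step beyond the scatter in this assay, namely a 1.2-fold lower number from compound 3 to compound 4 (0.08 log units; within the scatter). Compound 4 is accordingly estimated at 15000 nM in this assay, with a range from 5000 nM to 45000 nM.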

Compound 4, half-maximal inhibitory concentration: 14700 nM
The estimate for compound 4 lay 1.0-fold (0.01 log units) above the measured number; low and high end bracket the measured number.
By their numbers in this assay, from the lowest: compounds 2, 4, 3 and 1 (each within the scatter of the next).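

Replacing 2-fluorophenyl, with 0 hydrogen-bond donors, by 3,4-dihydroxyphenyl, with 2 hydrogen-bond donors, kept the number in this assay within the scatter (a 1.2-fold lower number from compound 3 to compound 4 (0.09 log units; within the scatter)). For the compounds shown here, the new group also stayed within the scatter of the other two groups (a 1.4-fold higher number from compound 2 to compound 4 (0.16 log units; within the scatter)) and (a 1.3-fold lower number from compound 1 to compound 4 (0.12 log units; within the scatter)), so no step among the four compounds at this carbon with a double bond to nitrogen leaves the scatter, even with hydroxyl groups on the ring. No independent measurement is available to explain why the numbers stay so close.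

All four groups here are substituted phenyl rings. The compounds shown leave open whether an amine or a carboxylic acid on that ring, or a longer chain in its place, would produce a step beyond the scatter.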